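Chloro to bromo on the pyridine ring of an aryl thioacetamide

This account rests on a few compounds, and the source may have more. Where it says the series, first, only, none or still open, it means among the compounds named here.

Measured so far in a functional assay on NCI-H460 cells (Homo sapiens) for antiproliferative activity, read by MTT assay, with a stated time of 48 h; on this read-out lower numbers stand for stronger inhibition and higher numbers for weaker inhibition:

compound 1 `COc1ccccc1C(=O)Nc1nnc(SCC(=O)Nc2ccc(Br)cn2)s1`: > 80000 nM, a limit of the assay
compound 2 `COc1ccccc1C(=O)Nc1nnc(SCC(=O)Nc2ccc(Cl)cn2)s1`: > 80000 nM, a limit of the assay
compound 3 `O=C(CCl)Nc1ccc(SCC(=O)Nc2ccc(Cl)cn2)cc1`: 420 nM

Compound 1 and compound 2 share a core; the difference between this core and that of compound 3 is not broken down here. Within the first pair the change is bromo in place of chloro on an aromatic carbon. The step that the two limits leave unreadable from compound 2 to compound 1 cannot be read, because both values sit at the limit of > 80000 nM in this assay, at which 2 of the 3 values shown sit. Among the measured compounds shown here, compound 3 is the only compound of the three with a number rather than a limit.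

Compound 4 `O=C(CCl)Nc1ccc(SCC(=O)Nc2ccc(Br)cn2)cc1` has not been measured. It differs from compound 3 by bromo in place of chloro on an aromatic carbon, which is the same change as that made from compound 2 to compound 1, and it is made at the same place. As far as these compounds go, since the measured instance of the change lies between two limits, its size is unknown, and no direction can be taken from it. In the absence of a readable size, the expectation for compound 4 in this assay is a step of about a 1.1-fold lower number from compound 3 to compound 4 (0.02 log units; within the scatter) from compound 3, that is, a value within the usual scatter of the value of compound 3, 420 nM. Compound 4 is therefore expected to give about 400 nM in this assay, in a range from 150 nM to 1100 nM.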

Compound 4, half-maximal inhibitory concentration: 530 nM
The estimate for compound 4 lay 1.3-fold (0.12 log units) below the measured number; measured number inside the range.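

In this assay, the change from 5-chloropyridin-2-yl to 5-bromopyridin-2-yl on the core of compound 3 gives a 1.3-fold higher number from compound 3 to compound 4 (0.10 log units; within the scatter), so on this core chloro and bromo at this place cannot be told apart. The same change on the core of compound 1 and compound 2 cannot be read, since both compounds give a limit of the assay and not a number: the limit of > 80000 nM in this assay, at which 2 of the 4 values shown sit. Among the compounds shown here, the series therefore holds only one readable instance of the change, which shows that bromo is tolerated as well as chloro on the core of compound 3 but does not show that the two cores respond alike, nor that the change would stay within the scatter on any other core.

With only chloro and bromo shown at this place, it remains open how a smaller or quite different group, such as a methyl, an amine or a carboxylic acid, would read on the core of compound 3. The difference between the two cores is also not broken down into single changes, so the compounds shown do not say which part of compound 3 and compound 4 separates them from compound 1 and compound 2, for instance whether the chloroacetyl group matters or an acetyl group would serve in its place.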